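Five-Membered Ring in Place of Pyridyl at the Para Position

This account rests on a few compounds, and the source may have more. Where it says the series, first, only, none or still open, it means among the compounds named here.

Compound 1 `Cc1cc(C)c(NC(=O)N(Cc2ccc(-c3nnc(C)o3)cc2)C2CCCCCC2)c(C)c1`: 27 nM
Compound 2 `Cc1cc(C)c(NC(=O)N(Cc2ccc(N3CCN(C)CC3)cc2)C2CCCCCC2)c(C)c1`: 57 nM
Compound 3 `Cc1cc(C)c(NC(=O)N(Cc2ccc(-c3cccnc3)cc2)C2CCCCCC2)c(C)c1`: 130 nM

All three were tested in an assay on microsomes from intestine for inhibition of acyl-CoA:cholesterol acyltransferase (Oryctolagus cuniculus); a lower number here means a stronger inhibitor, a higher number a weaker inhibitor. Compound 3 stands highest of the three numbers: the step of a 4.8-fold higher number from compound 1 to compound 3 (0.68 log units; beyond the scatter) and the step of a 2.3-fold higher number from compound 2 to compound 3 (0.36 log units; beyond the scatter) both place it beyond the scatter above the other two. Compound 4 `Cc1cc(C)c(NC(=O)N(Cc2ccc(-n3cccn3)cc2)C2CCCCCC2)c(C)c1` differs from compound 3 in one place: 1H-pyrazol-1-yl in place of pyridin-3-yl on an aromatic carbon. The step that bears most on this change is a 4.8-fold higher number from compound 1 to compound 3 (0.68 log units; beyond the scatter), where a five-membered aromatic ring with three hetero atoms was exchanged for the six-membered pyridin-3-yl and the number rose. Compound 4 now moves back from pyridin-3-yl to a five-membered ring, though one with two hetero atoms rather than three, so the reverse direction is expected, but not necessarily the full size of that step. The number for compound 4 is therefore expected to be lower than for compound 3, a 2.6-fold lower number from compound 3 to compound 4 (0.41 log units; beyond the scatter). Compound 4 is estimated at 50 nM, in the range 20 nM to 150 nM.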

Compound 4, half-maximal inhibitory concentration: 70 nM
The estimate for compound 4 lay 1.4-fold (0.15 log units) below the measured number, within the range that was stated.
By their numbers in this assay, from the lowest: compound 1; then compounds 2, 4 and 3 (each within the scatter of the next, the first and the last beyond it).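

In this assay, 1H-pyrazol-1-yl in place of pyridin-3-yl gives a 1.9-fold lower number from compound 3 to compound 4 (0.27 log units; within the scatter), so moving from the six-membered to a five-membered aromatic ring at this position does not by itself produce a clear shift. The 5-methyl-1,3,4-oxadiazol-2-yl group remains distinct, with a 2.6-fold higher number from compound 1 to compound 4 (0.41 log units; beyond the scatter), which shows that the two five-membered rings are not interchangeable here. The 1H-pyrazol-1-yl group also cannot be separated from 4-methylpiperazin-1-yl, with a 1.2-fold higher number from compound 2 to compound 4 (0.09 log units; within the scatter), although the two rings are very different in kind.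

Nothing available here explains these differences. The compounds shown also leave open whether the advantage of compound 1 lies with the methyl or with the third ring hetero atom, a question that a methyl-bearing pyrazole or an oxadiazole without the methyl could address.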